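The source may hold more compounds than are shown below. What is called first, only, known or untested is meant among the compounds shown, and "the series" means these compounds.

Measured so far in this series:
compound 1, `Cc1ccc2nc(C(=O)Nc3c(F)cc(-c4cccc(F)c4)cc3F)c(C)c(O)c2c1`, gives 11.2%
compound 2, `CCc1ccc2nc(C(=O)Nc3c(F)cc(-c4cccc(F)c4)cc3F)c(C)c(O)c2c1`, gives 23.5%
compound 3, `CCOc1ccc2nc(C(=O)Nc3c(F)cc(-c4cccc(F)c4)cc3F)c(C)c(C(=O)O)c2c1`, gives 17.9%

All three numbers come from a functional assay on Hep 3B2 cells (Homo sapiens) for antiproliferative activity, read by MTT assay, with a stated time of 24 h, tested at 1.23 ug/mL; a lower number here means a weaker effect, a higher number a stronger effect of the compound at the concentration tested. Among the compounds with values here, the only counted step between measured compounds is a number 12.3 percentage points lower from compound 2 to compound 1 (beyond the scatter), made by the change (hydrogen in place of methyl on a saturated chain carbon bound to an aromatic carbon). Compound 3 lies within the scatter of both compound 2 and compound 1, so no order among them is claimed; how the core of compound 3 differs from the core of compound 2 is not broken down here.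

Compound 4, `COc1ccc2nc(C(=O)Nc3c(F)cc(-c4cccc(F)c4)cc3F)c(C)c(C(=O)O)c2c1`, is not yet measured. It differs from compound 3 by hydrogen in place of methyl on a saturated chain carbon bound to an oxygen on an aromatic ring. Within the data shown here, this is the same kind of change as the one from compound 2 to compound 1, made in a different place: there on a saturated chain carbon bound to an aromatic carbon, here on a saturated chain carbon bound to an oxygen on an aromatic ring. It occurs twice among the compounds shown. In this assay, among the measured compounds shown here, a step of a number 6.9 percentage points lower from compound 3 to compound 4 (within the scatter) is expected, smaller than the one measured step, because a number 12.3 percentage points lower from compound 2 to compound 1 (beyond the scatter) was made on a different core and in a different place. Compound 4 is estimated at 11%, expected between 2% and 22%.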

Compound 4, a percentage reported as inhibition, at one concentration (the size of the read-out at that concentration, not a potency): 1.05%
Compound 4: the middle estimate sits 10 percentage points above what was measured; measured number below the stated range.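

In this assay the shortening of the chain, ethyl to methyl on one core and ethoxy to methoxy on the other, lowers the number both times, and the new case is a step of a number 16.9 percentage points lower from compound 3 to compound 4 (beyond the scatter) on the core of compound 3. Within these two pairs the change carries over from one core to the other with no size difference that can be told apart: the same change on two cores in this assay, a number 12.3 percentage points lower (beyond the scatter) from compound 2 to compound 1 and a number 16.9 percentage points lower (beyond the scatter) from compound 3 to compound 4, 4.6 percentage points apart, within the scatter of two such steps. This rests on two pairs at a single concentration, on a read-out that is not a potency, and the pairs differ in the attached atom as well as in the core, so it gives neither a rule for other cores in the series nor a reason for the fall.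

The compounds shown leave open whether the same trend continues to a longer chain such as propyl or propoxy. They also leave open what an amine in this place would give on either core.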